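Moving the Methoxy Group to Another Ring Position

This account rests on a few compounds, and the source may have more. Where it says the series, first, only, none or still open, it means among the compounds named here.

Among the compounds with values here, compound 2 `COc1ccccc1C1=NN(C(=S)Nc2ccccc2)C(c2ccc3c(c2)OCCO3)C1` carries the only number among the two values shown. In a functional assay on WM 266-4 cells (Homo sapiens) for antiproliferative activity, read by MTT assay, with a stated time of 48 h (a higher number here means a weaker inhibitor of growth, a lower number a stronger inhibitor of growth), compound 2 gives 25800 nM. Compound 1 `S=C(Nc1ccccc1)N1N=C(c2ccccc2Br)CC1c1ccc2c(c1)OCCO2` shows only a limit of this assay, > 200000 nM. Within the data shown here, the single measured step, an at least 7.7-fold lower number from compound 1 to compound 2 (0.88 log units; beyond the scatter), concerns a different change, methoxy in place of bromo, so it does not bear directly on the move considered here. Compound 3 `COc1cccc(C2=NN(C(=S)Nc3ccccc3)C(c3ccc4c(c3)OCCO4)C2)c1` differs from compound 2 by 3-methoxyphenyl in place of 2-methoxyphenyl on a carbon with a double bond to nitrogen. Among the measured compounds shown here, with no measured step of this kind, a step within the usual scatter is expected, a 1.2-fold higher number from compound 2 to compound 3 (0.07 log units; within the scatter). Compound 3 is expected to give about 30000 nM, between 8000 nM and 120000 nM.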

Compound 3, concentration for 50% growth inhibition: 1380 nM
Beside the measured number, compound 3's estimate is 22-fold (1.34 log units) above it; measured number outside the range, below it.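

In this assay, moving the methoxy group from 2-methoxyphenyl to 3-methoxyphenyl gives a 19-fold lower number from compound 2 to compound 3 (1.27 log units; beyond the scatter), so with the same atoms, where the methoxy group sits on this phenyl ring clearly matters. Replacing 2-bromophenyl with 3-methoxyphenyl gives an at least 140-fold lower number from compound 1 to compound 3 (2.16 log units; beyond the scatter). That step starts from a limit of the assay rather than a number: the limit of > 200000 nM in this assay, at which 1 of the 3 values shown sits.

From the compounds shown here alone, what stays open is whether an amine or a carboxylic acid in place of the methoxy group of 3-methoxyphenyl would keep this level of growth inhibition.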